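The source may hold more compounds than are shown below. What is called first, only, known or untested is meant among the compounds shown, and "the series" means these compounds.

Compound 1 `O=C1Nc2ccccc2/C1=C/c1ccc(-c2cn(-c3cccc(F)c3)nn2)cc1`: > 20000 nM
Compound 2 `O=C1Nc2ccccc2/C1=C/c1ccc(-c2cn(-c3ccc(Cl)c(C(F)(F)F)c3)nn2)cc1`: 9670 nM
Compound 3 `Cc1ccc(-n2cc(-c3ccc(/C=C4\C(=O)Nc5ccc(F)cc54)cc3)nn2)cc1`: 3980 nM

Compound 1 gives > 20000 nM, which is a limit of the assay and not a number.

In a functional assay on HT-29 cells (Homo sapiens) for inhibition, read by CCK-8 assay, with a stated time of 24 h (on this read-out lower numbers stand for stronger inhibition and higher numbers for weaker inhibition), compound 3 gives 3980 nM, the lower of the two true numbers, and compound 2 gives 9670 nM.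

Compound 4 `O=C1Nc2ccc(F)cc2/C1=C/c1ccc(-c2cn(-c3ccccc3Cl)nn2)cc1` differs from compound 3 by 2-chlorophenyl in place of 4-methylphenyl on an aromatic nitrogen.

Among the compounds with values here, only one measured step changes the group on this aromatic nitrogen: an at least 2.0-fold lower number from compound 1 to compound 2 (0.31 log units; beyond the scatter). Within the data shown here, it starts from a limit and belongs to the core of compound 1, so it shows only that such a swap can move the number, and it gives no firm direction here.

A modest weakening is tentatively expected in this assay, with the expected step being a 1.5-fold higher number from compound 3 to compound 4 (0.18 log units; within the scatter).

For compound 4, the estimated value is 6000 nM, with an expected range of 2000 nM to 20000 nM.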

Compound 4, half-maximal inhibitory concentration: 5950 nM
The estimate for compound 4 lay 1.0-fold (0.00 log units) above the measured number; low and high end bracket the measured number.
By their numbers in this assay, from the lowest: compounds 3, 4 and 2 (each within the scatter of the next, the first and the last beyond it). At a limit, above all of these: compound 1.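

In this assay, 2-chlorophenyl in place of 4-methylphenyl on this aromatic nitrogen gives a 1.5-fold higher number from compound 3 to compound 4 (0.17 log units; within the scatter), so on this core the two groups cannot be told apart. The earlier step at this position began from the limit of compound 1, whereas this pair gives a size between two true numbers. Nothing available here accounts for how close they are. From the compounds shown here alone, it remains open whether a non-aromatic group here, such as morpholine, or a phenyl ring carrying a carboxylic acid would move the number beyond the scatter.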